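Swapping the Thiourea Aryl Group: Compound 3 to Compound 4

The source may report more compounds than this note shows. Statements on the series, on what has been measured and on what is new or still open speak of the compounds shown alone.

Three compounds sharing one core were measured in a functional assay on MKN-74 cells (Homo sapiens) for antiproliferative activity, with a stated time of 24 h; a lower number here means a stronger inhibitor, a higher number a weaker inhibitor:

Compound 1 `NC(=O)c1c(NC(=O)c2ccccc2Cl)sc2c1CCN(Cc1ccccc1Cl)C2`: 4430 nM
Compound 2 `NC(=O)c1c(NC(=O)c2ccccc2Cl)sc2c1CCN(Cc1ccccc1F)C2`: 12900 nM
Compound 3 `NC(=O)c1c(NC(=O)c2ccccc2Cl)sc2c1CCN(C(=S)Nc1ccccc1Br)C2`: 10800 nM

Compound 3 gives the second highest number of the three. Its nearest neighbour is compound 2, which lies within the scatter of it, while compound 1 gives a clearly lower number: a 2.4-fold higher number from compound 1 to compound 3 (0.39 log units; beyond the scatter). Compound 1 and compound 2 differ only by one halogen on an aromatic ring, and that step was modest: a 2.9-fold higher number from compound 1 to compound 2 (0.46 log units; beyond the scatter). Between compound 2 and compound 3, a 1.2-fold lower number from compound 2 to compound 3 (0.08 log units; within the scatter).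

Compound 4 `NC(=O)c1c(NC(=O)c2ccccc2Cl)sc2c1CCN(C(=S)Nc1ccc(C(F)(F)F)cc1)C2` keeps the thiourea of compound 3 and changes only the aryl group on it: 4-(trifluoromethyl)phenyl in place of 2-bromophenyl on an amide-type nitrogen. Among the measured compounds shown here, none of the measured steps alters the aryl group on this thiourea nitrogen, so they bear on it only indirectly. For the measured compounds named here, the one halogen-to-halogen change on an aromatic ring, from compound 1 to compound 2, was modest, and the two ring-nitrogen substitutions were modest or within the scatter. A small step, if any, is therefore expected for compound 4 in this assay, with no clear direction. The estimate for compound 4 is 10000 nM, ranging from 3500 nM to 30000 nM, which amounts to an expected step of a 1.1-fold lower number from compound 3 to compound 4 (0.03 log units; within the scatter).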

Compound 4, half-maximal inhibitory concentration: 7090 nM
Compound 4: middle estimate off by 1.4-fold (0.15 log units), on the high side; the range from low to high includes it.
By their numbers in this assay, from the lowest: compounds 1, 4, 3 and 2 (each within the scatter of the next, the first and the last beyond it).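

Among the compounds shown here, this is the first measured change to the aryl group on the thiourea nitrogen: in this assay, placing 4-(trifluoromethyl)phenyl where 2-bromophenyl stood gives a 1.5-fold lower number from compound 3 to compound 4 (0.18 log units; within the scatter) and so does not separate the two compounds. At this position, then, 4-(trifluoromethyl)phenyl can take the place of 2-bromophenyl without a step beyond the scatter, even though the group attached to the phenyl ring and its place on that ring both change at once. Nothing measured here offers an explanation for this result.

Since both features change in the same step, the compounds shown cannot tell whether either one matters alone, or whether two opposing effects happen to cancel each other in this single pair. Also open, as far as these compounds go, is how this thiourea nitrogen would respond to a partner with no aromatic ring at all, such as a longer alkyl chain, or to a group carrying a carboxylic acid or an amine on the phenyl ring.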